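Phenyl to Fluoro: Expected Growth Inhibition of Compound 4

The source may hold more compounds than are shown below. What is called first, only, known or untested is meant among the compounds shown, and "the series" means these compounds.

Three measured compounds share one core. In a functional assay on DU-145 cells (Homo sapiens) for inhibition (a lower number here means a stronger inhibitor of growth, a higher number a weaker inhibitor of growth), compound 1 `C=C1CC(Cn2cc(C)c(=O)[nH]c2=O)(c2ccc(-c3ccccc3)cc2)OC1=O` gives 1660 nM. Compound 2 `C=C1CC(Cn2cc(C)c(=O)[nH]c2=O)(c2ccc(F)cc2)OC1=O` gives 7590 nM, and compound 3 `C=C1CC(Cn2ccc(=O)[nH]c2=O)(c2ccc(-c3ccccc3)cc2)OC1=O` gives 200 nM, the lowest of the three numbers; it stands apart from compound 1 by an 8.3-fold lower number from compound 1 to compound 3 (0.92 log units; beyond the scatter) and further still from compound 2.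

Compound 4 `C=C1CC(Cn2ccc(=O)[nH]c2=O)(c2ccc(F)cc2)OC1=O` differs from compound 3 by fluoro in place of phenyl on an aromatic carbon. Among the measured compounds shown here, one measured step bears on this change: a 4.6-fold higher number from compound 1 to compound 2 (0.66 log units; beyond the scatter). Nothing shows whether that change behaves the same once the methyl is absent, so a step of similar size and direction is simply expected, meaning compound 4 is expected to give a higher number than compound 3, a 4.5-fold higher number from compound 3 to compound 4 (0.65 log units; beyond the scatter). The estimate for compound 4 is 900 nM, with a range from 350 nM to 2500 nM.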

Compound 4, concentration for 50% growth inhibition: 15100 nM
The estimate for compound 4 lay 17-fold (1.22 log units) below the measured number, outside the stated range (above it).
By their numbers in this assay, from the lowest: compound 3; then compound 1; then compounds 2 and 4 (each within the scatter of the next).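

On the core without the methyl, fluoro in place of phenyl costs far more, with a 76-fold higher number from compound 3 to compound 4 (1.88 log units; beyond the scatter), so this change does not keep one size from core to core: the same change on two cores in this assay, a 4.6-fold higher number (0.66 log units; beyond the scatter) from compound 1 to compound 2 and a 76-fold higher number (1.88 log units; beyond the scatter) from compound 3 to compound 4, 17-fold (1.22 log units) apart, beyond the scatter of two such steps. Hydrogen in place of methyl helps with phenyl present, but with fluoro present it gives a 2.0-fold higher number from compound 2 to compound 4 (0.30 log units; within the scatter): the same change on two cores in this assay, an 8.3-fold lower number (0.92 log units; beyond the scatter) from compound 1 to compound 3 and a 2.0-fold higher number (0.30 log units; within the scatter) from compound 2 to compound 4, 17-fold (1.22 log units) apart, beyond the scatter of two such steps. The low number of compound 3 therefore depends on having phenyl and lacking the methyl together.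

Going by these compounds, it remains open whether another group on that aromatic carbon, such as an amine or a carboxylic acid, would behave like phenyl or like fluoro. These compounds also cannot tell why the two changes depend on each other.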